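Fluorine position on two benzyl groups: series notes

A few compounds are considered here, and "the series" means these few. Any claim that something is new, unique, unknown or untested is made for them only; others in the source may bear on it.

Measured so far in a functional assay on Huh-7 cells (Homo sapiens) for antiproliferative activity, read by sulforhodamine B assay, with a stated time of 72 h; a higher number here means a weaker inhibitor, a lower number a stronger inhibitor:
compound 1 `Fc1ccccc1COc1ccc(-c2cc(CN3CCN(Cc4ccc(C(F)(F)F)cc4)CC3)no2)cc1` gives 1500 nM
compound 2 `Fc1ccc(COc2ccc(-c3cc(CN4CCN(Cc5ccc(C(F)(F)F)cc5)CC4)no3)cc2)cc1` gives 2000 nM
compound 3 `N#Cc1cccc(COc2ccc(-c3cc(CN4CCN(Cc5ccc(F)cc5)CC4)no3)cc2)c1` gives 1600 nM

Compound 1 and compound 2 share a core and differ by 2-fluorophenyl in place of 4-fluorophenyl on a saturated chain carbon bound to an oxygen on an aromatic ring; the measured step is a 1.3-fold lower number from compound 2 to compound 1 (0.12 log units; within the scatter). The core of compound 3 is not that of compound 2, and the difference between the two cores is not broken down here; their two values lie within the scatter of each other.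

Compound 4 `N#Cc1cccc(COc2ccc(-c3cc(CN4CCN(Cc5ccccc5F)CC4)no3)cc2)c1` has not been measured. It differs from compound 3 by 2-fluorophenyl in place of 4-fluorophenyl on a saturated chain carbon bound to an amine nitrogen in a ring. This is the same kind of change as that made from compound 2 to compound 1, but not the same: there it sits on a saturated chain carbon bound to an oxygen on an aromatic ring, here on a saturated chain carbon bound to an amine nitrogen in a ring. Beside that earlier step, the expected step in this assay is a 1.1-fold lower number from compound 3 to compound 4 (0.06 log units; within the scatter), resting on compound 3 with 1600 nM and on the small size of a 1.3-fold lower number from compound 2 to compound 1 (0.12 log units; within the scatter). Compound 4 is thus estimated at 1400 nM, with a lower end of 800 nM and an upper end of 2600 nM.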

Compound 4, half-maximal inhibitory concentration: 2400 nM
Compound 4: the middle estimate sits 1.7-fold (0.23 log units) below what was measured, and the stated range covers the measured number.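

In this assay, 2-fluorophenyl in place of 4-fluorophenyl on a saturated chain carbon bound to an amine nitrogen in a ring gives a 1.5-fold higher number from compound 3 to compound 4 (0.18 log units; within the scatter). Set beside the earlier step, with its change on a saturated chain carbon bound to an oxygen on an aromatic ring, the two do not separate: the same change on two cores in this assay, a 1.3-fold lower number (0.12 log units; within the scatter) from compound 2 to compound 1 and a 1.5-fold higher number (0.18 log units; within the scatter) from compound 3 to compound 4, 2.0-fold (0.30 log units) apart, within the scatter of two such steps. Within these two pairs, the change stays small on both cores, but neither step has a direction that can be read, and two steps at different places on different cores do not show that its effect carries over or that it depends on the core.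

Still open, going by these compounds, is how the same change behaves at both places on a single core. The compounds shown also leave open whether a methoxy group or an amine in place of the fluorine on either benzyl group would give a step beyond the scatter.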